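From Formyl to Hydroxymethyl on the Shared Core

The source may report more compounds than this note shows. Statements on the series, on what has been measured and on what is new or still open speak of the compounds shown alone.

Of the compounds shown here, two have been measured so far in a functional assay on the whole organism (strain Wistar albino) for inhibition, with Rattus norvegicus as the target, read by paw edema, with a stated time of 3 h, at a dose of 100 mg/kg by the oral route; on this read-out lower numbers stand for less inhibition and higher numbers for more inhibition at the one dose given (going by the name of the read-out). Compound 1 `Cc1ccc2c(Cc3nn4c(C=O)c(-c5ccc(Cl)cc5)nc4s3)coc2c1` gives 42.5% in this assay. Among the compounds with values here, compound 2 `Cc1ccc2c(Cc3nn4c(C=O)c(-c5ccc(Br)cc5)nc4s3)coc2c1` gives 10.9%, the lower of the two numbers; the only measured step, a number 31.6 percentage points lower from compound 1 to compound 2 (beyond the scatter), lies beyond the scatter and consists of bromo in place of chloro on an aromatic carbon.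

Compound 3 `Cc1ccc2c(Cc3nn4c(CO)c(-c5ccc(Br)cc5)nc4s3)coc2c1` has not yet been measured. It differs from compound 2 in one place: hydroxymethyl in place of formyl on an aromatic carbon. Within the data shown here, no measured step touches the formyl group. Among the measured compounds shown here, the one known step, a number 31.6 percentage points lower from compound 1 to compound 2 (beyond the scatter), concerns bromo in place of chloro and offers no guide for an exchange of formyl for hydroxymethyl. There is therefore no ground in the measured steps for expecting a change beyond the scatter, and the expected step of a number 4.1 percentage points higher from compound 2 to compound 3 (within the scatter) is set accordingly. Compound 3 is estimated at 15% in this assay, with a range from 0% to 35%, the upper end allowing for a rise that the data cannot anticipate.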

Compound 3, a percentage reported as inhibition, in the whole organism at one dose (the size of the read-out at that dose, not a potency): 36.7%
Compound 3: middle estimate off by 21.7 percentage points, on the low side; measured number outside the range, above it.
By their numbers in this assay, from the lowest: compound 2; then compounds 3 and 1 (each within the scatter of the next).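

Hydroxymethyl in place of formyl gives the first measured change at this position in this assay and, with a number 25.8 percentage points higher from compound 2 to compound 3 (beyond the scatter), shows that the number responds to the group carried on this aromatic carbon of the five-membered aromatic ring, next to the ring nitrogen. The step lies beyond the scatter even though the two groups have the same count of heavy atoms, one carbon and one oxygen each, and neither has a ring; the counted differences are that formyl brings a double bond outside aromatic rings and no hydrogen-bond donor, whereas hydroxymethyl brings a hydrogen-bond donor. No measurement at hand bears on which of these differences, if either, goes with the step.

As far as these compounds go, the exchange is seen here only with the 4-bromophenyl group on the neighbouring ring atom, so whether it gives a step of like size with chloro in place of bromo remains open. Also open, from the compounds shown here alone, is how the number would respond to other groups at this position, such as a carboxylic acid, an amine or a longer chain ending in hydroxyl.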